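Cyano in place of fluoro: notes on the series

This account rests on a few compounds, and the source may have more. Where it says the series, first, only, none or still open, it means among the compounds named here.

Measured in a functional assay on NCI-H460 cells (Homo sapiens) for antiproliferative activity, read by sulforhodamine B assay, with a stated time of 72 h; on this read-out lower numbers stand for stronger inhibition and higher numbers for weaker inhibition
- compound 1 `O=C1CS/C(=N/Nc2nncc3ccccc23)N1` gives 19 nM
- compound 2 `Fc1ccc(Nc2nncc3ccccc23)cc1` gives 8.8 nM

Compound 2 stands at the lower of the two numbers, and its gap to compound 1 lies beyond the usual scatter. Among the measured compounds shown here, the two compounds do not differ in one place only, so the series holds no measured step that bears directly on the next change.

That change leads to compound 3 `N#Cc1ccc(Nc2nncc3ccccc23)cc1`, which has not yet been measured. It keeps the core of compound 2 and carries cyano in place of fluoro on an aromatic carbon, para to a large group (cyano in place of fluoro on an aromatic carbon). With only a single-group swap to judge and compound 2 at 8.8 nM as the starting point, a modest shift is the working expectation. In this assay the expected step of a 1.7-fold higher number from compound 2 to compound 3 (0.23 log units; within the scatter) is small, toward a higher number, and is estimated to stay within the scatter. The estimate for compound 3 is 15 nM with an expected range of 4 nM to 60 nM as the likely span.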

Compound 3, half-maximal inhibitory concentration: 7.7 nM
Compound 3: the middle estimate sits 1.9-fold (0.29 log units) above what was measured; measured number inside the range.
By their numbers in this assay, from the lowest: compounds 3 and 2 (each within the scatter of the next); then compound 1.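

In this assay the series now has its first comparison between compounds that differ in one place, and it gives a clear reading for cyano in place of fluoro on an aromatic carbon, para to a large group (a 1.1-fold lower number from compound 2 to compound 3 (0.06 log units; within the scatter)). At this position, on this core, the two groups cannot be told apart, even though cyano brings a triple bond and a hydrogen-bond acceptor that fluoro does not have, and compound 3 at 7.7 nM remains in the same low nanomolar range as its fluoro partner. No measurement in hand accounts for this close match, so it stands as an observation about one pair of compounds and offers no explanation.

Among the compounds shown here, whether the position tolerates groups of a different kind, such as an amine, a carboxylic acid or a longer chain, remains open, as the single step covers only fluoro and cyano. Also open, going by these compounds, is whether the same swap would read alike on another core or in another cell line, since compound 1 differs from both compounds in more than one place and cannot settle the question.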